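The source may hold more compounds than are shown below. What is called first, only, known or untested is meant among the compounds shown, and "the series" means these compounds.

Measured compounds:
- compound 1, `CN(C)CC(=O)NCC(=O)N(C)c1ccc(Cl)cc1C(=O)c1ccccc1Cl` — 26 mg/kg
- compound 2, `CCC(=O)NCC(=O)N(C)c1ccc(Cl)cc1C(=O)c1ccccc1Cl` — 36 mg/kg
- compound 3, `CN(C(=O)CNC(=O)c1ccccc1)c1ccc(Cl)cc1C(=O)c1ccccc1Cl` — > 100 mg/kg

In a functional assay on the whole organism with Mus musculus as the target, in the rotarod test (on this read-out higher numbers stand for an effect only at larger amounts of compound and lower numbers for an effect already at smaller amounts), compound 1 gives 26 mg/kg and compound 2 gives 36 mg/kg; the two values sit within the scatter of each other, as a 1.4-fold higher number from compound 1 to compound 2 (0.14 log units; within the scatter) shows. For compound 3 the assay reports only a limit, > 100 mg/kg, so its place on the scale is known from one side only; this is the limit of > 100 mg/kg in this assay, at which 1 of the 3 values shown sits.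

The unmeasured compound 4, `CN(C(=O)CNC(=O)CN1CCCCC1)c1ccc(Cl)cc1C(=O)c1ccccc1Cl`, differs from compound 3 as follows: (piperidin-1-yl)methyl in place of phenyl on a carbonyl carbon. This change undoes the kind of step seen in an at least 3.8-fold higher number from compound 1 to compound 3 (0.58 log units; beyond the scatter) and in an at least 2.7-fold higher number from compound 2 to compound 3 (0.44 log units; beyond the scatter), where a phenyl on the carbonyl carbon replaced a (dimethylamino)methyl or an ethyl and pushed the value out to the limit. Compound 4 carries a (piperidin-1-yl)methyl on that carbonyl carbon, a basic chain group like that of compound 1, so a lower number than the limit of compound 3 is expected, with a step of about an at least 3.3-fold lower number from compound 3 to compound 4 (0.52 log units; beyond the scatter). The estimate for compound 4 in this assay is 30 mg/kg, expected to fall between 12 mg/kg and 80 mg/kg.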

Compound 4, dose for half-maximal effect: > 100 mg/kg
Compound 4: no number, only a limit; the forecaster's own chance of this, stated with the estimate: 15%; at least 3.3-fold (0.52 log units) between middle value and limit.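

In this assay, a nitrogen on the saturated chain carbon bound to the carbonyl carbon does not by itself keep a compound off the limit: piperidin-1-yl in place of dimethylamino gives an at least 3.8-fold higher number from compound 1 to compound 4 (0.58 log units; beyond the scatter). The chain of compound 2, which carries no such nitrogen, also stays clear of the limit, and piperidin-1-yl in place of its methyl gives an at least 2.7-fold higher number from compound 2 to compound 4 (0.44 log units; beyond the scatter). The step from compound 3 to compound 4 cannot be read, and both benzoyl and ((piperidin-1-yl)methyl)carbonyl end at the same limit: the limit of > 100 mg/kg in this assay, at which 2 of the 4 values shown sit.

As far as these compounds go, it stays open whether the jump follows the ring itself or the amine as a whole; pyrrolidin-1-yl, morpholin-4-yl or diethylamino on the same chain carbon would separate these. From the compounds shown here alone, how far compound 3 and compound 4 lie beyond their limits also remains unknown.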